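Moving the hydroxyl from 3-hydroxyphenyl to 4-hydroxyphenyl

This account rests on a few compounds, and the source may have more. Where it says the series, first, only, none or still open, it means among the compounds named here.

Among the compounds with values here, in a physicochemical assay for solubility, read by spectrophotometry, in phosphate buffer, with a stated time of 18 h, at pH 7.4 (on this read-out lower numbers stand for lower solubility and higher numbers for higher solubility), compound 1 `CCc1ccc(-c2nc3c(c(C)nn3-c3ccccc3)c(-c3ccccc3C)c2C#N)cc1` gives 6000 nM and compound 2 `CCc1ccc(-c2nc3c(c(C)nn3-c3ccccc3)c(-c3cccc(O)c3)c2C#N)cc1` gives 18000 nM as the higher of the two numbers so far. The change to compound 3 `CCc1ccc(-c2nc3c(c(C)nn3-c3ccccc3)c(-c3ccc(O)cc3)c2C#N)cc1` is 4-hydroxyphenyl in place of 3-hydroxyphenyl on an aromatic carbon at a place opposite the ring nitrogen and ortho to a cyano group. Within the data shown here, the one measured step that bears on this is a 3.0-fold higher number from compound 1 to compound 2 (0.48 log units; beyond the scatter) and it is modest. It put 3-hydroxyphenyl in place of 2-methylphenyl rather than shifting a hydroxyl, so it is only a loose guide. In this assay a step no larger than that one is therefore expected, probably none beyond the scatter and with no favoured direction. The expected step is a 1.2-fold lower number from compound 2 to compound 3 (0.08 log units; within the scatter) as a rough estimate. For compound 3 the estimated value is 15000 nM with an expected range of 6000 nM to 35000 nM in this measurement.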

Compound 3, solubility: 5700 nM
Compound 3: the middle estimate sits 2.6-fold (0.42 log units) above what was measured; the measured number lies below the stated range.
By their numbers in this assay, from the lowest: compounds 3 and 1 (each within the scatter of the next); then compound 2.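

In this assay, the placing of the hydroxyl on this phenyl group proves to count: with the same atoms joined differently, 4-hydroxyphenyl in place of 3-hydroxyphenyl gives a 3.2-fold lower number from compound 2 to compound 3 (0.50 log units; beyond the scatter). Set against 2-methylphenyl, 4-hydroxyphenyl gives only a 1.1-fold lower number from compound 1 to compound 3 (0.02 log units; within the scatter), so among these three compounds a hydroxyl alone does not go with a higher number, and compound 3 is the one that goes against such a pattern. Nothing available here accounts for the difference between the two hydroxyl placements.

Going by these compounds, it remains open whether 2-hydroxyphenyl would fall with compound 2 or with compound 3. Also open, on these data alone, is whether 3-methoxyphenyl or 3-aminophenyl in place of 3-hydroxyphenyl would keep the number of compound 2.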